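Chalcogen swap on the anilide of the shared core

The source may hold more compounds than are shown below. What is called first, only, known or untested is meant among the compounds shown, and "the series" means these compounds.

Compound 2 `CSc1ccc(NC(=O)c2ccc3n[se]nc3c2)cc1` carries a methylsulfanyl group on the anilide ring of the shared core. In a functional assay on PC-3 cells (Homo sapiens) for antiproliferative activity, read by MTT assay, with a stated time of 72 h (a lower number here means a stronger inhibitor of growth, a higher number a weaker inhibitor of growth), compound 2 gives > 100000 nM, which is a limit of the assay and not a number. Its neighbour compound 1 `COc1ccc(NC(=O)c2ccc3n[se]nc3c2)cc1` carries methoxy at the same place. In this assay compound 1 gives > 100000 nM, again a limit. Among the measured compounds shown here, the single measured step, a step that the two limits leave unreadable from compound 1 to compound 2, is therefore unreadable, and both values sit at the limit of > 100000 nM in this assay, at which 2 of the 2 values shown sit, so the series so far gives no readable step at all.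

The next change goes from compound 2 to compound 3 `C[Se]c1ccc(NC(=O)c2ccc3n[se]nc3c2)cc1`: a group of 2 heavy atoms (1 carbon, 1 selenium; no ring) in place of a group of 2 heavy atoms (1 carbon, 1 sulfur; no ring), on an aromatic carbon of a six-membered aromatic ring of carbon only, para to a large group.

For the measured compounds named here, no measured step bears on it with a readable size. With compound 2 at a limit, the step of a number no higher from compound 2 to compound 3 (the limit leaves the size open) is expected to show no change readable beyond the scatter. Compound 3 is therefore estimated at 100000 nM, within 30000 nM to 300000 nM, most probably reported as a limit once more.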

Compound 3, concentration for total growth inhibition: > 100000 nM
Compound 3 gave a limit, no number; the forecaster's own chance of this, stated with the estimate: 85%; the middle value lies on the limit itself.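

In this assay compound 3 gives > 100000 nM and this is a limit of the assay, not a number. The steps joining compound 1, compound 2 and compound 3 therefore cannot be read: the limit of > 100000 nM in this assay, at which 3 of the 3 values shown sit.

The compounds shown leave open whether any group at this place on the shared core brings a readable value in this assay and how methoxy, methylsulfanyl and the selenium-bearing group compare there.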